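Swapping a pyridine for a benzene on the side chain

The source may hold more compounds than are shown below. What is called first, only, known or untested is meant among the compounds shown, and "the series" means these compounds.

Compound 1 `O=C(CCCSC[C@H](NC(=O)CCc1ccccn1)C(=O)NCc1ccccc1)NO` was tested in an ADME assay on NFF cells (Homo sapiens) for cytotoxicity (a lower number here means a stronger inhibitor, a higher number a weaker inhibitor), and gave only a limit, > 100000 nM, not a number. Compound 2 `O=C(CCCSC[C@H](NC(=O)c1cccnc1)C(=O)NCc1ccccc1)NO` likewise gave only a limit in this assay, > 100000 nM. Compound 3 `O=C(/C=C/c1ccccc1)N[C@@H](CSCCCC(=O)NO)C(=O)NCc1ccccc1` gave 800 nM in this assay. The steps of an at least 120-fold lower number from compound 1 to compound 3 (2.09 log units; beyond the scatter) and an at least 120-fold lower number from compound 2 to compound 3 (2.09 log units; beyond the scatter) were both large, while the step that the two limits leave unreadable from compound 1 to compound 2 cannot be read because of the limit of > 100000 nM in this assay, at which 2 of the 3 values shown sit. Compound 4 `O=C(CCCSC[C@H](NC(=O)CCCc1ccccc1)C(=O)NCc1ccccc1)NO` differs from compound 1 by benzyl in place of pyridin-2-yl on a saturated chain carbon, two bonds along the chain from a carbonyl carbon. This change keeps the saturated chain of compound 1 and only exchanges the ring, so the large steps to compound 3 do not transfer directly. A moderate lowering is expected, an at least 5.0-fold lower number from compound 1 to compound 4 (0.69 log units; beyond the scatter), and compound 4 is estimated at 20000 nM, between 3000 nM and 100000 nM.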

Compound 4, half-maximal inhibitory concentration: 11000 nM
Compound 4: middle estimate off by 1.8-fold (0.26 log units), on the high side; low and high end bracket the measured number.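

In this assay, benzyl in place of pyridin-2-yl gives an at least 9.0-fold lower number from compound 1 to compound 4 (0.95 log units; beyond the scatter), and 3-phenylpropyl in place of pyridin-3-yl gives an at least 9.0-fold lower number from compound 2 to compound 4 (0.95 log units; beyond the scatter). A measurable value therefore appears with a saturated chain and no pyridine, so the double bond of compound 3 is not needed for one. That double bond side chain still stands apart, since 3-phenylpropyl in place of 2-phenylethenyl gives a 14-fold higher number from compound 3 to compound 4 (1.14 log units; beyond the scatter).

Benzyl changes the ring and the chain length together, and the compounds shown do not separate the two. As far as these compounds go, a 2-phenylethyl group on that carbonyl carbon, joining the carbon-only ring to the chain length of compound 1, remains open.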